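The compounds below may be only part of what the source reports. "The series", "measured", "known", "first", "only" and "open" are said of these compounds alone.

Series notes. In a functional assay on IMR-90 cells for antagonist activity at B1 bradykinin receptor (Homo sapiens), read by calcium flux (on this read-out lower numbers stand for stronger inhibition and higher numbers for weaker inhibition), compound 1 `CC(=O)Nn1c(NCc2ccc(-c3cc(Cl)cc(F)c3-c3noc(C)n3)cc2F)nc(C)c1C` gives 180 nM, and compound 2 `CC(=O)Nn1ccnc1NCc1ccc(-c2cc(Cl)cc(F)c2-c2noc(C)n2)cc1F` gives 1.6 nM. Within the data shown here, the one step measured so far, a 110-fold lower number from compound 1 to compound 2 (2.05 log units; beyond the scatter), concerns only the substitution of the imidazolyl group on the amine nitrogen and leaves compound 2 with the lowest of the two numbers. Compound 3 `COc1cc(C(=O)Nn2ccnc2NCc2ccc(-c3cc(Cl)cc(F)c3-c3noc(C)n3)cc2F)on1` keeps the whole of compound 2 except the amide substituent: 3-methoxy-1,2-oxazol-5-yl in place of methyl on a carbonyl carbon. Among the measured compounds shown here, no measured pair touches the carbonyl carbon, so the step from compound 1 to compound 2 does not bear on this change and nothing in the numbers gathered so far points in either direction. On that footing the working expectation for compound 3 is a step of a 1.3-fold higher number from compound 2 to compound 3 (0.10 log units; within the scatter), not beyond the scatter. Compound 3 is therefore estimated in this assay at 2 nM, with a range of 0.5 nM to 8 nM.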

Compound 3, half-maximal inhibitory concentration: 1.7 nM
Beside the measured number, compound 3's estimate is 1.2-fold (0.07 log units) above it; measured number inside the range.
By their numbers in this assay, from the lowest: compounds 2 and 3 (each within the scatter of the next); then compound 1.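

At the carbonyl carbon, a 1.1-fold higher number from compound 2 to compound 3 (0.03 log units; within the scatter) in this assay shows that the single methyl can be replaced by 3-methoxy-1,2-oxazol-5-yl with no change beyond the scatter. The entering group has 7 heavy atoms and a five-membered aromatic ring, so this position accepts a much larger substituent in this one pair. Among these compounds, the earlier step concerned only the imidazolyl group on the amine nitrogen, and this is the first reading at the carbonyl carbon.

On these data alone, it remains open whether a 1,2-oxazol-5-yl group without the methoxy, a phenyl ring, a primary amine or a carboxylic acid would fit this carbonyl carbon equally well. Also open, as far as these compounds go, is how the 4,5-dimethyl-substituted imidazolyl group of compound 1 would read with the 3-methoxy-1,2-oxazol-5-yl amide in place. No independent measurement offers an explanation for this result.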